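Adding an Acetamido Group to Compound 1

A few compounds are considered here, and "the series" means these few. Any claim that something is new, unique, unknown or untested is made for them only; others in the source may bear on it.

Three measured compounds share a core joined through an ether chain to a charged, oxygen-bearing ring. Compound 1 `COc1cc2ccc(=O)oc2cc1OCCOc1no[n+]([O-])c1S(=O)(=O)c1ccccc1` is the starting point here. In a functional assay on MCF7 cells (Homo sapiens) for inhibition, read by MTT assay, with a stated time of 48 h, tested at 10 uM (on this read-out higher numbers stand for more inhibition at the one concentration tested (going by the name of the read-out) and lower numbers for less inhibition), compound 1 gives 89.2%. Compound 2 `COc1cc2ccc(=O)oc2cc1OCCCCOc1no[n+]([O-])c1S(=O)(=O)c1ccccc1`, with a longer chain, gives 84.4% in this assay, and compound 3 `COc1cc2ccc(=O)oc2cc1OCCCCCCOc1c[n+]([O-])on1` gives 84.8%. Compound 1 holds the highest of the three numbers, yet both other values lie within the usual scatter of it, so the three cannot be told apart.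

Compound 4 `COc1cc2cc(NC(C)=O)c(=O)oc2cc1OCCOc1no[n+]([O-])c1S(=O)(=O)c1ccccc1` has not yet been measured. It differs from compound 1 in one place: acetamido in place of hydrogen on an aromatic carbon. Among the compounds with values here, no pair of measured compounds shows a change of this kind, so there is no step to lean on. Because compound 1 already gives 89.2%, little room remains above it, and the step of a number 7.2 percentage points lower from compound 1 to compound 4 (within the scatter) is expected to stay within the scatter, tending if anything slightly downward. Compound 4 is therefore estimated at 82%, within a range from 65% to 92%.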

Compound 4, a percentage reported as inhibition, at one concentration (the size of the read-out at that concentration, not a potency): 83.7%
Compound 4: middle estimate off by 1.7 percentage points, on the low side; the measured number falls inside the stated range.
By their numbers in this assay, from the lowest: compounds 4, 2, 3 and 1 (each within the scatter of the next).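

Replacing hydrogen with acetamido gives a number 5.5 percentage points lower from compound 1 to compound 4 (within the scatter) in this assay. Within the data shown here, all three earlier compounds carry hydrogen at this aromatic carbon, so compound 4 is the first to show that this position can take a group of 4 heavy atoms, including a hydrogen-bond donor, with no change beyond the scatter of this read-out. Nothing measured here bears on why the added group leaves the number within the scatter.

As far as these compounds go, whether an amine or a carboxylic acid at the same carbon would also stay within the scatter remains open, as does the effect of acetamido on the longer chains of compound 2 and compound 3. From the compounds shown here alone, a reading at one concentration is also not a potency, so any difference in potency between compound 1 and compound 4 remains unknown.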